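Amide to Ring: an Expected Gain in Half-life

This account rests on a few compounds, and the source may have more. Where it says the series, first, only, none or still open, it means among the compounds named here.

Measured so far in an ADME assay on microsomes from liver (Homo sapiens) for metabolic stability; a higher number here means that the compound lasts longer, a lower number that the compound disappears faster:
- compound 1 `CC(C)NC(=O)CC(c1ccc(-c2ccc3cccc(F)c3c2)[nH]c1=O)C(C)C` gives 0.32 h
- compound 2 `CC(C)C(c1ccc(-c2ccc3cccc(F)c3c2)[nH]c1=O)N1CCN/C1=N\C#N` gives 0.632 h
- compound 3 `CC(C)C(c1noc(=O)[nH]1)c1ccc(-c2ccc3cccc(F)c3c2)[nH]c1=O` reaches > 3 h in this assay, a limit rather than a number.

Compound 1 and compound 2 lie close together: a 2.0-fold higher number from compound 1 to compound 2 (0.30 log units; within the scatter). Compound 3 sits at the limit of > 3 h in this assay, at which 1 of the 3 values shown sits. Compound 4 `CC(C)C(Cc1noc(=O)[nH]1)c1ccc(-c2ccc3cccc(F)c3c2)[nH]c1=O` is not yet measured. Compared with compound 1 it carries a group of 6 heavy atoms (2 carbon, 2 nitrogen, 2 oxygen; one five-membered aromatic ring with 3 hetero atoms) in place of a group of 6 heavy atoms (4 carbon, 1 nitrogen, 1 oxygen; no ring), on a saturated chain carbon, two bonds along the chain from an aromatic carbon. The measured steps that bear on this bring the same five-membered aromatic ring into compound 3: an at least 9.3-fold higher number from compound 1 to compound 3 (0.97 log units; beyond the scatter) and an at least 4.7-fold higher number from compound 2 to compound 3 (0.67 log units; beyond the scatter). Both rises lie beyond the scatter, so a rise in this assay is expected for compound 4 as well, though here the ring sits on a saturated chain carbon, two bonds along the chain from an aromatic carbon, and replaces a different group, so a more modest estimated gain: a 5.6-fold higher number from compound 1 to compound 4 (0.75 log units; beyond the scatter). Compound 4 is thus expected at 1.8 h, between 0.7 h and 4 h.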

Compound 4, half-life: > 3 h
Compound 4 ended at the assay's limit; the forecaster's own chance of this, stated with the estimate: 30%; middle value at least 1.6-fold (0.22 log units) away from the limit.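

The five-membered aromatic ring with 3 hetero atoms also lengthens the half-life when it sits on a saturated chain carbon, two bonds along the chain from an aromatic carbon, not only in its placement in compound 3. In this assay, replacing isopropylcarbamoyl gives an at least 9.3-fold higher number from compound 1 to compound 4 (0.97 log units; beyond the scatter), and the comparison with the other ring-bearing compound gives an at least 4.7-fold higher number from compound 2 to compound 4 (0.67 log units; beyond the scatter). The step from compound 3 to compound 4 cannot be read, because both compounds stand at a limit: the limit of > 3 h in this assay, at which 2 of the 4 values shown sit.

Which placement of the ring lasts longer therefore remains open. So does whether a carboxylic acid in place of the ring, or a longer chain carrying it, would last as long.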